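Phenyl for methyl on the shared core

The compounds below may be only part of what the source reports. "The series", "measured", "known", "first", "only" and "open" are said of these compounds alone.

Of the compounds shown here, two have been tested in a functional assay on the whole organism (artery, strain mongrel) for inhibition, with Canis familiaris (Canis lupus familiaris) as the target, with a stated time of 20 min, at a dose of 4.58 mg/kg by the intravenous route; on this read-out lower numbers stand for a weaker effect and higher numbers for a stronger effect at the one dose given. Compound 1 `CC(C)(C)NCC(O)COc1ncns1` gives 50%. Compound 2 `Cc1nsc(OCC(O)CNC(C)(C)C)n1` gives 55.5%. Within the data shown here, the only difference between them is a methyl in place of hydrogen on an aromatic carbon, and a number 5.5 percentage points higher from compound 1 to compound 2 (within the scatter), so the two numbers cannot be set apart and compound 2 is simply the one whose number happens to lie higher on the sheet.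

Compound 3 `CC(C)(C)NCC(O)COc1nc(-c2ccccc2)ns1` is not yet measured. It keeps the shared core and the side chain of compound 2, and differs only in this: phenyl in place of methyl on an aromatic carbon. Among the measured compounds shown here, the single earlier step at this same aromatic carbon, from hydrogen to methyl, moved the read-out by a number 5.5 percentage points higher from compound 1 to compound 2 (within the scatter), which gives no hint of a trend in either direction. For the measured compounds named here, no earlier step introduces a ring at that position, so there is nothing to say whether a larger group helps or hurts, and the expectation is a step of about a number 2.5 percentage points lower from compound 2 to compound 3 (within the scatter), which is expected to stay inside the scatter. Compound 3 is therefore estimated at 53%, with a range from 30% to 75%. Going by the values given here, the range is kept wide: no measured step here swaps a methyl for a ring, so the data give no narrower footing.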

Compound 3, a percentage reported as inhibition, in the whole organism at one dose (the size of the read-out at that dose, not a potency): 41.5%
Compound 3: the middle estimate sits 11.5 percentage points above what was measured; the range from low to high includes it.
By their numbers in this assay, from the lowest: compounds 3, 1 and 2 (each within the scatter of the next, the first and the last beyond it).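

In this assay, among these compounds, the aromatic carbon between two ring nitrogen atoms now shows that what it carries can matter: replacing methyl, with 1 heavy atom, by phenyl, with 6 heavy atoms, gives a number 14 percentage points lower from compound 2 to compound 3 (beyond the scatter), the first step at this position to clear the scatter. The comparison with hydrogen reads differently, with a number 8.5 percentage points lower from compound 1 to compound 3 (within the scatter), so the phenyl ring stands apart from methyl but not from hydrogen, and the three compounds form no simple line from small to large group. No independent measurement is available to explain this difference between the methyl and phenyl compounds.

The compounds shown leave open whether the lower number belongs to phenyl alone or would also appear with another group at this carbon, such as a longer chain like butyl or a saturated ring like cyclohexyl. From the compounds shown here alone, it also remains open how a phenyl ring carrying a chlorine atom or a methoxy group would compare with compound 3, and whether an amine or a carboxylic acid on this carbon would give a number closer to that of compound 2.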